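Ring-closing the amine side chain in a dioxolane series

This account rests on a few compounds, and the source may have more. Where it says the series, first, only, none or still open, it means among the compounds named here.

Compound 3 `CCNC[C@H]1COC(c2ccccc2)(c2ccccc2)O1` gives 8400 nM in a functional assay (brain) for displacement of a labelled ligand, with Rattus norvegicus as the target (on this read-out lower numbers stand for stronger inhibition and higher numbers for weaker inhibition), the highest number among the three measured compounds. Its nearest neighbour is compound 1 `CN1CCCC[C@H]1[C@H]1COC(c2ccccc2)(c2ccccc2)O1`, which gives 4400 nM; the step of a 1.9-fold higher number from compound 1 to compound 3 (0.28 log units; within the scatter) is within the scatter. Compound 2 `CN[C@@H](C)[C@H]1COC(c2ccccc2)(c2ccccc2)O1` gives 703 nM, and the step of a 12-fold higher number from compound 2 to compound 3 (1.08 log units; beyond the scatter) is large. Compound 4 `c1ccc(C2(c3ccccc3)OC[C@H]([C@@H]3CCCN3)O2)cc1` differs from compound 3 in one place: pyrrolidin-2-yl in place of (ethylamino)methyl on a saturated ring carbon.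

Going by the values given here, two measured steps bear on this change. Among the compounds with values here, both compound 1 and compound 2 carry the nitrogen on a carbon that is joined directly to the shared core, as compound 4 does, and both give lower numbers than compound 3, although only the step from compound 2 lies beyond the scatter. Compound 4 combines a ring, as in compound 1, with a secondary amine, as in compound 2. A modest drop in the number is therefore expected, the step of a 5.6-fold lower number from compound 3 to compound 4 (0.75 log units; beyond the scatter). For compound 4 the expected value in this assay is 1500 nM, with a range from 400 nM to 6000 nM.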

Compound 4, inhibition constant: > 10000 nM
Compound 4 gave a limit, no number (the forecaster's own chance of this, stated with the estimate: 5%); middle value at least 6.6-fold (0.82 log units) from the limit.
By their numbers in this assay, from the lowest: compound 2; then compounds 1 and 3 (each within the scatter of the next). At a limit, above all of these: compound 4.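

Compound 4 gives a limit rather than a number in this assay: the limit of > 10000 nM in this assay, at which 1 of the 4 values shown sits. Having the nitrogen on a carbon joined directly to the shared core therefore does not by itself give a lower number, and pyrrolidin-2-yl compares poorly with both groups that carry the nitrogen in this way, with an at least 14-fold higher number from compound 2 to compound 4 (1.15 log units; beyond the scatter) and an at least 2.2-fold higher number from compound 1 to compound 4 (0.35 log units; beyond the scatter). Against the open-chain (ethylamino)methyl group only a floor can be read, an at least 1.1-fold higher number from compound 3 to compound 4 (0.07 log units; that floor lies within the scatter), so compound 3 and compound 4 cannot be ordered.

As far as these compounds go, it remains open how far beyond its limit compound 4 lies. Also open, from the compounds shown here alone, is whether piperidin-2-yl or 1-methylpyrrolidin-2-yl on this saturated ring carbon would give a measurable number in this assay.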